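Adding a methyl to the ring of compound 2

This account rests on a few compounds, and the source may have more. Where it says the series, first, only, none or still open, it means among the compounds named here.

Measured in a functional assay on the whole organism for agonist activity, with Mus musculus as the target; on this read-out lower numbers stand for an effect already at smaller amounts and higher numbers for an effect only at larger amounts of compound:
- compound 1 `CCc1nccn1CC#CCN1CCCC1=O`: > 100 mg/kg (a limit)
- compound 2 `CC(=O)N(C)C(C)C#CCn1ccnc1`: 3 mg/kg
- compound 3 `CC(=O)N(C)C(C)C#CCn1cncc1C`: > 100 mg/kg (a limit)

Within the data shown here, compound 2, at 3 mg/kg, holds the only actual number. The results for compound 1 and compound 3 are limits. The measured range is bounded by the limit of > 100 mg/kg in this assay, at which 2 of the 3 values shown sit.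

Compound 4 `CC(=O)N(C)C(C)C#CCn1ccnc1C` is derived from compound 2 through methyl in place of hydrogen on an aromatic carbon, between two ring nitrogen atoms.

Among the measured compounds shown here, the one measured step of this kind is an at least 33-fold higher number from compound 2 to compound 3 (1.52 log units; beyond the scatter). It is the same replacement, though not on the same ring carbon, so it is a guide to direction more than to exact size. A large step towards a higher number is therefore expected in this assay, possibly somewhat smaller than the measured one, and a result at the limit remains possible. The expected change is a 10-fold higher number from compound 2 to compound 4 (1.00 log units; beyond the scatter). Compound 4 is estimated at 30 mg/kg, with an expected range of 5 mg/kg to 200 mg/kg.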

Compound 4, dose for half-maximal effect: > 100 mg/kg
Compound 4: a limit, no number; the forecaster's own chance of this, stated with the estimate: 40%; at least 3.3-fold (0.52 log units) between middle value and limit.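

In this assay, methyl in place of hydrogen on an aromatic carbon, between two ring nitrogen atoms, gives an at least 33-fold higher number from compound 2 to compound 4 (1.52 log units; beyond the scatter). Compound 3 carried the same replacement on a different ring carbon, so with compound 4 the shift to a higher number is no longer tied to a single ring carbon. The size of the change at this position stays a lower bound, and the two ring carbons cannot be ranked against each other, with compound 3 and compound 4 both resting on the same limit: the limit of > 100 mg/kg in this assay, at which 3 of the 4 values shown sit.

Open, from the compounds shown here alone, is whether fluorine or an amine on this carbon would keep a value close to that of compound 2, at 3 mg/kg. Also open, going by these compounds, is how far beyond the limit compound 3 and compound 4 actually lie.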